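From 2-methylphenyl to 4-bromophenyl at the limit of measurement

A few compounds are considered here, and "the series" means these few. Any claim that something is new, unique, unknown or untested is made for them only; others in the source may bear on it.

Measured compounds:
Compound 1 `O=C(CCC1=CCCN(Cc2ccc(F)cc2)C1=O)NO`: "not determined" (no result reported)
Compound 2 `O=C(CCC1=CCCN(Cc2ccc(NC(=O)c3ccccc3)cc2)C1=O)NO`: > 10000 nM
Compound 3 `Cc1ccccc1CN1CCC=C(CCC(=O)NO)C1=O`: > 10000 nM

These compounds share one core and were examined in a functional assay on PC-3 cells (Homo sapiens) for inhibition, read by sulforhodamine B assay; on this read-out higher numbers stand for weaker inhibition of growth and lower numbers for stronger inhibition of growth. Compound 1 has no number to offer, as its entry of "not determined" (no result reported) shows. Compound 2 gives > 10000 nM, which is a limit and not a number. Compound 3 gives > 10000 nM, which is likewise a limit and not a number. The picture so far is therefore (the limit of > 10000 nM in this assay, at which 2 of the 3 values shown sit), and compound 3 has no measured number against which it could be placed.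

The next compound to be tested is compound 4 `O=C(CCC1=CCCN(Cc2ccc(Br)cc2)C1=O)NO`. It carries 4-bromophenyl in place of 2-methylphenyl on a saturated chain carbon bound to an amide-type nitrogen in a ring. Among the compounds with values here, no two measured compounds differ in one place only, so the data offer no measured step to serve as a guide. The expectation rests on compound 3, whose value of > 10000 nM is a limit. The expected change, a number no higher from compound 3 to compound 4 (the limit leaves the size open), is none beyond the usual scatter, and no direction is foreseen. A report of only a limit in this assay is expected to be the likeliest outcome. The estimated value for compound 4 is 10000 nM, with an expected range from 3000 nM to 30000 nM.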

Compound 4, concentration for 50% growth inhibition: 3150 nM
Estimate against measurement, compound 4: 3.2-fold (0.50 log units) above; the measured number falls inside the stated range.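

In this assay, the exchange of 2-methylphenyl for 4-bromophenyl on a saturated chain carbon bound to an amide-type nitrogen in a ring gives an at least 3.1-fold lower number from compound 3 to compound 4 (0.50 log units; beyond the scatter), the first sign that growth inhibition in this series responds to the group carried at this place. Within the same series, bromo in place of benzamido on an aromatic carbon gives an at least 3.1-fold lower number from compound 2 to compound 4 (0.50 log units; beyond the scatter), so the two changes that lead to compound 4 both end in a lower number, though the true size of each step stays unknown. Compound 4 is the only compound shown that has a number in this assay, and the remaining measured compounds give no more than a limit: the limit of > 10000 nM in this assay, at which 2 of the 4 values shown sit.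

In this assay, as far as these compounds go, compound 1 gives "not determined" (no result reported), so it remains open whether fluoro on the aromatic carbon would behave as bromo does. Also open, from the compounds shown here alone, is how a chloro group, an amine or a carboxylic acid on that aromatic carbon would compare with compound 4, and whether the lower number belongs to bromo itself or needs the 4-bromophenyl arrangement as a whole.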